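This account rests on a few compounds, and the source may have more. Where it says the series, first, only, none or still open, it means among the compounds named here.

Measured compounds:
Compound 1 `O=C(Nc1cccc(Oc2ccccn2)c1)C1CCCN(C(=O)c2cc(C(F)(F)F)cc(C(F)(F)F)c2)C1`: 0%
Compound 2 `COC(=O)c1cccc(C(=O)N2CCCC(C(=O)Nc3ccc(Cl)cc3)C2)c1`: 0%
Compound 3 `O=C(Nc1cccc(CN2CCCC2)c1)C1CCCN(C(=O)c2cc(C(F)(F)F)cc(C(F)(F)F)c2)C1`: 51%

In an ADME assay on PC-3 cells (Homo sapiens) for cytotoxicity, read by WST assay, tested at 100 uM (a higher number here means more inhibition at the concentration tested (going by the name of the read-out), a lower number less inhibition), compound 2 gives 0%, level with compound 1 at the digits shown; together they are the lowest of the three numbers. Furthest from compound 2 stands compound 3, with a reading 51%. Among the compounds with values here, the one measured step, a number 51 percentage points higher from compound 1 to compound 3 (beyond the scatter), is large. That step changes the anilide side of the shared core. The new compound 4 `O=C(Nc1ccc(Cl)cc1)C1CCCN(C(=O)c2cccc(-c3cccs3)c2)C1` keeps the anilide of compound 2 and instead changes the benzoyl ring: thiophen-2-yl in place of methoxycarbonyl on an aromatic carbon. Within the data shown here, no measured step covers a change at that place, so the size of the step cannot be read from the data. Because compound 2 sits at 0%, the reading can only stay or rise; a step that may be none beyond the scatter, or a modest rise, is expected. Compound 4 is therefore estimated at 10%, in the range 0% to 35%. This corresponds to an expected step of a number 10 percentage points higher from compound 2 to compound 4 (within the scatter).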

Compound 4, a percentage reported as inhibition, at one concentration (the size of the read-out at that concentration, not a potency): 4%
Estimate against measurement, compound 4: 6 percentage points above; measured number inside the range.
By their numbers in this assay, from the lowest: compounds 1, 2 and 4 (each within the scatter of the next); then compound 3.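

In this assay, within the data shown here, putting thiophen-2-yl in place of methoxycarbonyl on the six-membered aromatic ring of carbon only gives a number 4 percentage points higher from compound 2 to compound 4 (within the scatter), the first reading of a change at this position. Here, then, two groups with quite different make-up, one with a ring containing sulfur and one with no ring at all, give readings that cannot be told apart, unlike the large step on the anilide side of the shared core, a number 51 percentage points higher from compound 1 to compound 3 (beyond the scatter). No measured evidence bears on why these two groups read alike.

As far as these compounds go, whether an open-chain amine or a carboxylic acid at this position would give a higher reading remains open. Also open, from the compounds shown here alone, is whether thiophen-2-yl would read the same when paired with the anilide of compound 3.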